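Moving the hydroxyl: from compound 1 to compound 4

The source may hold more compounds than are shown below. What is called first, only, known or untested is meant among the compounds shown, and "the series" means these compounds.

In an assay on HEK293 cells for displacement of a labelled ligand from D(3) dopamine receptor (Rattus norvegicus) (a higher number here means a weaker inhibitor, a lower number a stronger inhibitor), compound 1 `CCCN(CCN1CCN(c2ccc(-c3cccc(OC)c3)cc2)CC1)C1CCc2nc(N)sc2C1` gives 2.11 nM, the second highest of the three numbers at hand. Compound 2 `CCCN(CCN1CCN(c2ccc(-c3ccc(O)cc3)cc2)CC1)C1CCc2nc(N)sc2C1` gives 1.17 nM; the change a 1.8-fold lower number from compound 1 to compound 2 (0.26 log units; within the scatter) lies within the scatter. For the measured compounds named here, compound 3 `CCCN(CCN1CCN(c2ccc(-c3cccc(O)c3)cc2)CC1)[C@@H]1CCc2nc(N)sc2C1` gives 19.7 nM, a weaker inhibitor than compound 1, but it also differs in the set stereocentre of the shared core, so no single step connects the two. Compound 4 `CCCN(CCN1CCN(c2ccc(-c3ccccc3O)cc2)CC1)C1CCc2nc(N)sc2C1` carries 2-hydroxyphenyl in place of 3-methoxyphenyl on an aromatic carbon. Going by the values given here, the one step that bears on it, a 1.8-fold lower number from compound 1 to compound 2 (0.26 log units; within the scatter), shows a hydroxyphenyl replacing the methoxyphenyl without a change beyond the scatter, while compound 3 shows that a hydroxyl elsewhere, together with a set stereocentre, can go with a much higher number. Compound 4 is therefore expected to be somewhat weaker, with a 2.4-fold higher number from compound 1 to compound 4 (0.37 log units; beyond the scatter). The estimate for compound 4 is 5 nM, within a range of 1.5 nM to 20 nM.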

Compound 4, inhibition constant: 1.8 nM
Compound 4: the middle estimate sits 2.8-fold (0.44 log units) above what was measured; the measured number falls inside the stated range.
By their numbers in this assay, from the lowest: compounds 2, 4 and 1 (each within the scatter of the next); then compound 3.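

In this assay, 2-hydroxyphenyl in place of 3-methoxyphenyl gives a small step (a 1.2-fold lower number from compound 1 to compound 4 (0.07 log units; within the scatter)), and 2-hydroxyphenyl in place of 4-hydroxyphenyl gives another (a 1.5-fold higher number from compound 2 to compound 4 (0.19 log units; within the scatter)). On this aromatic carbon, para to a large group, compound 1, compound 2 and compound 4 therefore stay within the scatter of one another, so moving the hydroxyl to the 2-position leaves no readable change. No measurement shown here explains this. Still open, on these data alone, is whether an amine or a carboxylic acid on this ring would keep the number in the same range.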